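Replacing 1H-indazol-4-yl with 1H-benzimidazol-6-yl

The source may report more compounds than this note shows. Statements on the series, on what has been measured and on what is new or still open speak of the compounds shown alone.

Compound 1 `CNC(=O)c1cc(C(=O)NC2CC2)cn(Cc2cccc([C@@H](C)O)c2)c1=O`: >= 131 ug/mL (a limit)
Compound 2 `CNC(=O)c1cc(C(=O)NC2CC2)cn(Cc2cccc3[nH]ncc23)c1=O`: 10 ug/mL

Among the compounds with values here, in a physicochemical assay for solubility (on this read-out higher numbers stand for higher solubility and lower numbers for lower solubility), compound 2 gives 10 ug/mL, the only actual number so far. Compound 1 reaches only a limit, >= 131 ug/mL.

Compound 3 `CNC(=O)c1cc(C(=O)NC2CC2)cn(Cc2ccc3nc[nH]c3c2)c1=O` keeps the core of compound 2 and differs on a saturated chain carbon bound to an aromatic nitrogen: 1H-benzimidazol-6-yl in place of 1H-indazol-4-yl on a saturated chain carbon bound to an aromatic nitrogen. The two have the same atoms, joined differently.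

Within the data shown here, one measured step touches this place: an at least 13-fold lower number from compound 1 to compound 2 (1.11 log units; beyond the scatter). That large step removed a 3-(1-hydroxyethyl)phenyl group, whereas the counted features stay the same here, so a change of that size is not expected. No measurement compares these two groups directly. In this assay, the expected change is small and upward: a 1.8-fold higher number from compound 2 to compound 3 (0.26 log units; within the scatter). For compound 3 the estimate is 18 ug/mL, with an expected range of 6 ug/mL to 70 ug/mL.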

Compound 3, solubility: >= 163 ug/mL
Compound 3 was reported as a limit; the forecaster's own chance of this, stated with the estimate: 10%; at least 9.0-fold (0.95 log units) between middle value and limit.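

In this assay, 1H-benzimidazol-6-yl in place of 1H-indazol-4-yl on a saturated chain carbon bound to an aromatic nitrogen gives an at least 16-fold higher number from compound 2 to compound 3 (1.21 log units; beyond the scatter). The two groups have the same atoms and the same counted features, so at this place a different joining of those atoms alone is enough for a large step, which the earlier change from 3-(1-hydroxyethyl)phenyl to 1H-indazol-4-yl could not show, as it exchanged one group for an altogether different one. Compound 3 stands at a limit, not at a number: the limit of >= 163 ug/mL in this assay, at which 1 of the 3 values shown sits.

The step between compound 1 and compound 3 cannot be read, as both stand at limits. Going by these compounds, it also remains open how this assay would read with an aminomethyl or a carboxylic acid on the 1H-benzimidazol-6-yl group.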